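The source may report more compounds than this note shows. Statements on the series, on what has been measured and on what is new or still open speak of the compounds shown alone.

Compound 1, `COc1cccc(-c2n[nH]c(-c3ccc(Cl)cc3C)n2)c1`, gives 0.04 mg/kg in a functional assay on the whole organism (Cricetulus griseus) with Cricetinae gen. sp. as the target; on this read-out lower numbers stand for an effect already at smaller amounts and higher numbers for an effect only at larger amounts of compound.
Compound 2, `COc1cccc(-c2n[nH]c(-c3ccc(C)cc3C)n2)c1`, gives 0.04 mg/kg.
Compound 3, `Cc1ccc(Cl)cc1-c1n[nH]c(-c2ccccc2)n1`, gives 1.2 mg/kg.

Compound 4, `Cc1ccc(C)c(-c2n[nH]c(-c3ccccc3)n2)c1`, has not yet been measured. It comes from compound 3 by one change: methyl in place of chloro on an aromatic carbon. The same kind of change links the two measured compounds 1 and 2: methyl in place of chloro on an aromatic carbon. That change produced no change at the digits printed from compound 1 to compound 2 (within the scatter). The surroundings of the changed carbon are not identical, though: in the measured pair it is meta to a methyl group and para to a large group, while in the new pair it is meta to a large group and para to a methyl group. The difference between the cores of compound 1 and compound 3 is not broken down here; the numbers alone show that compound 3 needs a far larger dose than compound 1 or compound 2.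

Compound 4 is expected to stay close to compound 3, with an expected step of no change at the digits printed from compound 3 to compound 4 (within the scatter), because the earlier exchange of chloro for methyl gave no change at the digits printed from compound 1 to compound 2 (within the scatter). Compound 4 is therefore estimated at 1.2 mg/kg, with a likely range from 0.4 mg/kg to 3.6 mg/kg.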

Compound 4, dose for half-maximal effect: > 10 mg/kg
Compound 4 ended at the assay's limit; the forecaster's own chance of this, stated with the estimate: 5%; middle value at least 8.3-fold (0.92 log units) from the limit.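

The exchange of chloro for methyl does not carry over unchanged between the two cores in this series, so the result from the first pair could not be relied on for the second: the same change on two cores in this assay, no change at the digits printed (within the scatter) from compound 1 to compound 2 and an at least 8.3-fold higher number (0.92 log units; beyond the scatter) from compound 3 to compound 4, at least 8.3-fold (0.92 log units) apart, beyond the scatter of two such steps

On the second core the exchange gives an at least 8.3-fold higher number from compound 3 to compound 4 (0.92 log units; beyond the scatter), but these two pairs do not show whether the core as a whole sets the outcome or the surroundings of the changed carbon, which here is meta to a large group and para to a methyl group. In this assay, going by these compounds, compound 4 gives > 10 mg/kg, which is a limit of the assay and not a number, so the full size of the step stays unknown.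

For the compounds shown here, with only two pairs, it remains open how the same exchange would turn out on further cores. On these data alone, it is also open whether a different group on this carbon, such as fluoro or an amine, would stay closer to compound 3 than methyl does.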